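Working notes: dimethylamino for piperidin-1-yl on the carbonyl

The source may report more compounds than this note shows. Statements on the series, on what has been measured and on what is new or still open speak of the compounds shown alone.

Measured so far in a physicochemical assay for solubility, in phosphate buffer, at pH 7.4; a lower number here means a less soluble compound, a higher number a more soluble compound (two compounds):
- compound 1 `CNC(=O)CN1CCC(c2cc3c(-c4ccc(=O)n(C(C)C)c4)ccnc3[nH]2)CC1` gives 34000 nM
- compound 2 `CC(C)n1cc(-c2ccnc3[nH]c(C4CCN(CC(=O)N5CCCCC5)CC4)cc23)ccc1=O` gives 79000 nM

Going by the values given here, compound 2 holds the higher of the two numbers at 79000 nM and has compound 1 as its only measured neighbour. Next in the series is compound 3 `CC(C)n1cc(-c2ccnc3[nH]c(C4CCN(CC(=O)N(C)C)CC4)cc23)ccc1=O` which has dimethylamino in place of piperidin-1-yl on a carbonyl carbon and otherwise matches compound 2.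

Among the compounds with values here, one measured step bears on this change. It is a 2.3-fold higher number from compound 1 to compound 2 (0.37 log units; beyond the scatter) and it is modest, with piperidin-1-yl replacing methylamino at that same carbonyl carbon. Within the data shown here, no measured compound carries dimethylamino, so this single step is a loose guide. Since compound 3 also gives up the ring, a lower number in this assay is expected, of no more than modest size. The estimated change is a 1.6-fold lower number from compound 2 to compound 3 (0.20 log units; within the scatter) and it may not stand clear of the scatter. The expected value for compound 3 is 50000 nM with a range of 25000 nM to 100000 nM for this estimate.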

Compound 3, solubility: 110000 nM
The estimate for compound 3 lay 2.2-fold (0.34 log units) below the measured number; measured number above the stated range.
By their numbers in this assay, from the lowest: compound 1; then compounds 2 and 3 (each within the scatter of the next).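

In this assay, dimethylamino can replace piperidin-1-yl on this carbonyl carbon without a difference that clears the scatter, with a 1.4-fold higher number from compound 2 to compound 3 (0.14 log units; within the scatter) as the step, so the ring is not needed here to keep the number at the level of compound 2. The step from the secondary amide gives the sharper contrast, with a 3.2-fold higher number from compound 1 to compound 3 (0.51 log units; beyond the scatter), and it places methyl on the amide-type nitrogen where compound 1 has the amide hydrogen. Among these three compounds, compound 1 stands apart from compounds 2 and 3, which both lack the amide hydrogen and stay within the scatter of each other, and nothing at hand gives a reason for this result.

From the compounds shown here alone, whether this grouping extends beyond these three compounds remains open, as a morpholine or azetidine on the same carbonyl carbon could stay with compounds 2 and 3, while a primary amide could fall with compound 1 or below it. Also open, going by these compounds, is how a carboxylic acid in place of the amide, or a longer chain carrying the same amide, would read in this assay.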